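This account rests on a few compounds, and the source may have more. Where it says the series, first, only, none or still open, it means among the compounds named here.

Compound 2 `COc1ccc(-c2c3ccc4ccccc4c3nc3c2c(C)nc2c4ccccc4ccc32)cc1` stands with the highest of the two numbers reported in a functional assay on HeLa cells (Homo sapiens) for cytotoxicity, read by MTT assay, with a stated time of 48 h (on this read-out higher numbers stand for weaker inhibition and lower numbers for stronger inhibition), where compound 2 gives 45900 nM. Compound 1 `Cc1nc2c3ccccc3ccc2c2nc3c(ccc4ccccc43)c(-c3nccnc3N)c12` gives 1210 nM. Compound 3 `Cc1nc2c3ccccc3ccc2c2nc3c(ccc4ccccc43)c(-c3ccccc3Cl)c12` reaches only the assay limit of > 80000 nM. The step of a 38-fold higher number from compound 1 to compound 2 (1.58 log units; beyond the scatter) is large, as is an at least 66-fold higher number from compound 1 to compound 3 (1.82 log units; beyond the scatter), whereas an at least 1.7-fold higher number from compound 2 to compound 3 (0.24 log units; that floor lies within the scatter) stays within the scatter. Compound 4 `Cc1nc2c3ccccc3ccc2c2nc3c(ccc4ccccc43)c(-c3cc(O)nc4ccccc34)c12` differs from compound 2 by 2-hydroxyquinolin-4-yl in place of 4-methoxyphenyl on an aromatic carbon. Going by the values given here, no measured step tests this particular exchange; the two exchanges of one aryl group for another seen so far point in opposite directions and in different sizes. The estimate for compound 4 is therefore a value of 20000 nM, between 4000 nM and 80000 nM, which is expected to mean a step of a 2.3-fold lower number from compound 2 to compound 4 (0.36 log units; beyond the scatter).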

Compound 4, half-maximal inhibitory concentration: 4880 nM
Compound 4: the middle estimate sits 4.1-fold (0.61 log units) above what was measured, within the range that was stated.
By their numbers in this assay, from the lowest: compound 1; then compound 4; then compound 2. At a limit, above all of these: compound 3.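

In this assay, placing 2-hydroxyquinolin-4-yl on this aromatic carbon opposite the ring nitrogen gives a 9.4-fold lower number from compound 2 to compound 4 (0.97 log units; beyond the scatter), and an at least 16-fold lower number from compound 3 to compound 4 (1.21 log units; beyond the scatter), so among the four compounds both aryl groups with a ring nitrogen give lower numbers than the two phenyl groups. Compound 3 stands at a limit of the assay, not at a number: the limit of > 80000 nM in this assay, at which 1 of the 4 values shown sits. The new group still does not match 3-aminopyrazin-2-yl, with a 4.0-fold higher number from compound 1 to compound 4 (0.61 log units; beyond the scatter). The compounds shown leave open whether the hydroxyl or the ring nitrogen of 2-hydroxyquinolin-4-yl carries this step, and how an aliphatic amine or a carboxylic acid would fare at this position.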